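Alkenyl versus saturated ether chains on two acetylphenol cores

The source may hold more compounds than are shown below. What is called first, only, known or untested is meant among the compounds shown, and "the series" means these compounds.

Measured compounds in a functional assay on HeLa cells (Homo sapiens) for cytotoxicity, read by XTT assay, with a stated time of 72 h; a lower number here means a stronger inhibitor, a higher number a weaker inhibitor:
- compound 1, `CCCCCCCC/C=C\CCCCCCCCOc1cc(O)c(C(C)=O)c(O)c1`: 31000 nM
- compound 2, `CCCCCCCC/C=C\CCCCCCCCOc1cc(O)cc(O)c1C(C)=O`: > 100000 nM, a limit of the assay
- compound 3, `CCCCCCCCCCCCCCCCCCOc1cc(O)c(C(C)=O)c(O)c1`: > 100000 nM, a limit of the assay

Compound 1 and compound 2 are built from the same atoms joined differently; the difference between the two cores is not broken down here. Within the core of compound 1, the change decyl in place of dec-1-en-1-yl on a saturated chain carbon, eight bonds along the chain from an oxygen on an aromatic ring gives an at least 3.2-fold higher number from compound 1 to compound 3 (0.50 log units; beyond the scatter). Compound 3 sits at the limit described by the limit of > 100000 nM in this assay, at which 2 of the 3 values shown sit, so the true size of that step is not known, only that it is at least modest.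

Compound 4, `CCCCCCCCCCCCCCCCCCOc1cc(O)cc(O)c1C(C)=O`, is not yet measured. It stands to compound 2 as compound 3 stands to compound 1: the change decyl in place of dec-1-en-1-yl on a saturated chain carbon, eight bonds along the chain from an oxygen on an aromatic ring is the same change, at the same place, as in the measured pair. For compound 2 in this assay only a limit is known. Since compound 2 already sits at that limit and the measured step, from compound 1 to compound 3, went toward weaker inhibition, compound 4 is expected to remain at or beyond the limit, and the step that the limit leaves unreadable from compound 2 to compound 4 is estimated to be small or unmeasurable. Compound 4 is expected to give about 200000 nM in this assay, with a range of 100000 nM to 1000000 nM, most likely reported as a limit.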

Compound 4, half-maximal inhibitory concentration: > 100000 nM
Compound 4 gave a limit, no number; the forecaster's own chance of this, stated with the estimate: 90%; the middle value does not contradict the limit.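

Compound 2 and compound 4 both sit at a limit, not a number, in this assay, so no step between them can be read: the limit of > 100000 nM in this assay, at which 3 of the 4 values shown sit.

The compounds shown leave open how far compound 2, compound 3 and compound 4 lie past that limit, and so whether decyl in place of dec-1-en-1-yl changes anything within the core of compound 2.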